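This account rests on a few compounds, and the source may have more. Where it says the series, first, only, none or still open, it means among the compounds named here.

Of the compounds shown here, three have been measured in an assay on isolated protein for inhibition of Polyunsaturated fatty acid 5-lipoxygenase (Homo sapiens), read by HPLC, with stated times of 15 min and 10 min; on this read-out lower numbers stand for stronger inhibition and higher numbers for weaker inhibition. Compound 1 `FC(F)(F)c1ccc(Nc2nc(-c3ccc(Cl)cc3)cs2)cc1` gives 600 nM there and stands second highest of the three numbers. Its nearest neighbour is compound 3 `Nc1ccc(-c2csc(Nc3ccc(O)cc3)n2)cc1`, which gives 400 nM, a gap that lies within the usual scatter, so no order between the two can be claimed. Its furthest neighbour is compound 2 `Oc1cccc(Nc2nc(-c3ccccc3)cs2)c1`, which gives 3700 nM, a gap beyond the scatter, so compound 2 shows the weaker inhibition of that pair.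

Compound 4 `Clc1ccc(-c2csc(Nc3ccccc3)n2)cc1` has not yet been measured. It differs from compound 1 in one place: hydrogen in place of trifluoromethyl on an aromatic carbon, para to a large group. Among the compounds with values here, no measured pair shows this change, so the expectation rests on the three values alone. The step is expected to be a 2.0-fold higher number from compound 1 to compound 4 (0.30 log units; within the scatter), a modest loss of inhibition that may only just exceed the scatter. Compound 4 is expected to give about 1200 nM, within a range from 400 nM to 4000 nM.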

Compound 4, half-maximal inhibitory concentration: 700 nM
The estimate for compound 4 lay 1.7-fold (0.23 log units) above the measured number; measured number inside the range.
By their numbers in this assay, from the lowest: compounds 3, 1 and 4 (each within the scatter of the next); then compound 2.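

In this assay, hydrogen in place of trifluoromethyl on an aromatic carbon, para to a large group, gives a 1.2-fold higher number from compound 1 to compound 4 (0.07 log units; within the scatter) and lies within the scatter. This pair is the first among the compounds shown to isolate a single change, and it shows that the number can stay within the scatter without trifluoromethyl at this position. No measured information on either group bears on this result.

The pair leaves open whether a carboxylic acid or a nitrile at the same position would give a number beyond the scatter from that of compound 4. Compound 2 and compound 3 differ from compound 4 in more than one place, so they cannot show whether the same change would give a similar step on a different core.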